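Chloro for Methoxy on a Sulfonyl Hydrazide

This account rests on a few compounds, and the source may have more. Where it says the series, first, only, none or still open, it means among the compounds named here.

Of the compounds shown here, two have been measured in an assay on HeLa cells for inhibition of Indoleamine 2,3-dioxygenase 1 (Homo sapiens), read by spectrophotometry, with a stated time of 24 h; a lower number here means that less compound is needed, a higher number that more compound is needed for the effect. Compound 1, `Cc1cccc(NNS(=O)(=O)c2ccc(C(=O)NCC(=O)O)cc2)c1`, gives 271 nM. Compound 2, `COc1ccc(NNS(=O)(=O)c2ccc(NC(C)=O)cc2)cc1`, reaches only a limit of the assay, recorded as > 10000 nM, so no number is known for it. This is the limit of > 10000 nM in this assay, at which 1 of the 2 values shown sits. Compound 3, `CC(=O)Nc1ccc(S(=O)(=O)NNc2ccc(Cl)cc2)cc1`, differs from compound 2 in one place: chloro in place of methoxy on an aromatic carbon. Among the measured compounds shown here, no measured pair shows this change, so its direction is open. Compound 3 is expected to remain weak, at about 9000 nM, within 2500 nM to 30000 nM. The expected step from compound 2 to compound 3 is an at least 1.1-fold lower number from compound 2 to compound 3 (0.04 log units; that floor lies within the scatter).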

Compound 3, half-maximal effective concentration: 142 nM
Compound 3: the middle estimate sits 63-fold (1.80 log units) above what was measured, outside the stated range (below it).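

Chloro in place of methoxy at this place on the ring gives an at least 70-fold lower number from compound 2 to compound 3 (1.84 log units; beyond the scatter) in this assay, so this single swap on the shared core can separate a compound that stays at the assay limit from one with a measured value. The true step may be larger still, because compound 2 stands at a limit and not at a number: the limit of > 10000 nM in this assay, at which 1 of the 3 values shown sits.

The compounds shown leave open how a fluoro, a bromo or an amine at this place would read. They therefore cannot tell whether chloro is especially favourable here or methoxy especially unfavourable.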